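From methoxy to tert-butyl on an aromatic carbon

The source may hold more compounds than are shown below. What is called first, only, known or untested is meant among the compounds shown, and "the series" means these compounds.

Measured so far in a functional assay on A549 cells (Homo sapiens) for inhibition, read by CCK-8 assay, with a stated time of 72 h, tested at 2 uM (a lower number here means less inhibition of growth, a higher number more inhibition of growth at the concentration tested), are three compounds
compound 1 `CCc1ccc(SCc2ccc(/C=C/C(=O)Nc3ccccc3N)cc2)cc1` gives 60.7%
compound 2 `COc1ccc(SCc2ccc(C(=O)Nc3ccccc3N)cc2)cc1` gives 45.7%
compound 3 `Nc1ccccc1NC(=O)/C=C/c1ccc(CSc2ccc(F)cc2)cc1` gives 51.2%

Compound 2 stands within the scatter of compound 3, while compound 1 lies beyond the scatter above it. The next step leads to compound 4 `CC(C)(C)c1ccc(SCc2ccc(C(=O)Nc3ccccc3N)cc2)cc1` and is tert-butyl in place of methoxy on an aromatic carbon in all, tert-butyl in place of methoxy on an aromatic carbon. Among the compounds with values here, only one measured step bears on it. That exchange, fluoro in place of ethyl on an aromatic carbon, gave a number 9.5 percentage points lower from compound 1 to compound 3 (within the scatter) and involves neither group in question. An estimated step of a number 4.3 percentage points higher from compound 2 to compound 4 (within the scatter) is therefore expected, which means no change beyond the scatter in this assay. For compound 4 the expected value is 50%, with an estimated range from 33% to 66%.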

Compound 4, percent growth inhibition at one concentration: 38.6%
For compound 4 the middle estimate is 11.4 percentage points above the measured one; the range from low to high includes it.
By their numbers in this assay, from the lowest: compounds 4, 2, 3 and 1 (each within the scatter of the next, the first and the last beyond it).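

In this assay, the exchange on the aromatic carbon para to a large group gives a number 7.1 percentage points lower from compound 2 to compound 4 (within the scatter). On the core of compound 2, this position therefore accepts tert-butyl, with more heavy atoms and no hydrogen-bond acceptor, in place of methoxy without a change beyond the scatter, which the step on the core of compound 1 could not show. Nothing available explains this outcome. Going by these compounds, whether an amine or a carboxylic acid at this position would shift growth inhibition beyond the scatter remains open. So does whether tert-butyl would behave alike on the core of compound 1.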